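Removing One Aromatic Fluorine: A Whole-Animal Toxicity Step

The source may hold more compounds than are shown below. What is called first, only, known or untested is meant among the compounds shown, and "the series" means these compounds.

Compound 1, `O=C(O)c1cc(F)c(F)c(F)c1O`: 0%
Compound 2, `O=C(O)c1ccc(F)c(F)c1O`: 33%
Compound 3, `CC(=O)Oc1c(F)c(F)c(F)c(F)c1C(=O)O`: 0%

Three compounds have so far been run in a toxicity assay on the whole organism (strain CD-1) for cytotoxicity, with Mus musculus as the target, with a stated time of 14 days, at a dose of 300 mg/kg by the intraperitoneal route; a higher number here means a weaker effect of the compound at the dose given, a lower number a stronger effect. Compound 1 and compound 2 share a core and differ in one place: hydrogen in place of fluoro on an aromatic carbon. In this assay this change gave a number 33 percentage points higher from compound 1 to compound 2 (beyond the scatter). Compound 3 stands level with compound 1 at the digits printed, within the scatter, and the two together are the lowest of the three numbers; against compound 2 it is the same number of points lower. How the core of compound 3 differs from the core of compound 1 is not broken down here.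

Compound 4, `CC(=O)Oc1c(C(=O)O)cc(F)c(F)c1F`, has not yet been measured. It differs from compound 3 in one place: hydrogen in place of fluoro on an aromatic carbon. Within the data shown here, this is the same kind of change as the one from compound 1 to compound 2, but the surroundings are not the same. In the earlier pair the hydrogen enters ortho to a fluoro group, meta to a carboxy group, meta to a fluoro group and para to a hydroxy group; in the new pair it enters ortho to a carboxy group, ortho to a fluoro group, meta to a fluoro group, meta to an acetoxy group and para to a fluoro group.

Among the measured compounds shown here, because compound 3 gives 0%, and because the only measured instance of this kind of change gave a number 33 percentage points higher from compound 1 to compound 2 (beyond the scatter), a step of similar direction is expected. For compound 4 a step of a number 30 percentage points higher from compound 3 to compound 4 (beyond the scatter) is estimated. In this assay compound 4 is therefore expected to give about 30%, most likely between 0% and 60%; the differing surroundings make this expectation loose.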

Compound 4, a percentage reported as activity, at one dose (the size of the read-out at that dose, not a potency): 0%
Beside the measured number, compound 4's estimate is 30 percentage points above it; measured number inside the range.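

In this assay, hydrogen in place of fluoro on an aromatic carbon gave no change at the digits printed from compound 3 to compound 4 (within the scatter), while acetyl in place of hydrogen on an oxygen on an aromatic ring gave no change at the digits printed from compound 1 to compound 4 (within the scatter). Set beside the earlier instance, the same kind of change did not carry from one core to the other: the same change on two cores in this assay, a number 33 percentage points higher (beyond the scatter) from compound 1 to compound 2 and no change at the digits printed (within the scatter) from compound 3 to compound 4, 33 percentage points apart, beyond the scatter of two such steps This shows that, in this small series, the outcome of removing one aromatic fluorine at this dose cannot be taken from one core to another, but it does not show whether the acetyl on the oxygen, the different place at which the hydrogen enters, or both together lie behind the gap, and two pairs give no rule for a third core.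

The compounds shown leave open what the acetyl in place of hydrogen on an oxygen would do on the core of compound 2, which would set that change on a second core. They also leave open how the series would read with chlorine or an amine in place of fluoro on the aromatic carbon, or with a longer chain than acetyl on the oxygen.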